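The source may report more compounds than this note shows. Statements on the series, on what has been measured and on what is new or still open speak of the compounds shown alone.

Working notes on the series. In an assay on isolated protein for inhibition of RAC-alpha serine/threonine-protein kinase (Homo sapiens), read by mobility shift assay, tested at 30 uM (on this read-out lower numbers stand for less inhibition and higher numbers for more inhibition at the one concentration tested (going by the name of the read-out)), compound 2 `Cn1nc(N)c2c(=O)[nH]c(-c3ccccc3)cc21` gives 8%, the second highest of the three numbers measured. Compound 3 `Cn1nc(N)c2c(=O)[nH]c(-c3ccccn3)cc21` gives 7% in this assay, a change of a number 1 percentage points lower from compound 2 to compound 3 (within the scatter) for pyridin-2-yl in place of phenyl on an aromatic carbon. For the measured compounds named here, compound 1 `COc1ccc(-c2cc3[nH]nc(N)c3c(=O)[nH]2)cc1` gives 21% in this assay, higher than compound 2 beyond the scatter, but it differs from compound 2 in two places and no single step is known for it. Compound 4 `COc1ccc(-c2cc3c(c(N)nn3C)c(=O)[nH]2)cc1` differs from compound 2 by methoxy in place of hydrogen on an aromatic carbon. Going by the values given here, no measured step bears directly on this change; the only single step known, from compound 2 to compound 3, was within the scatter, while compound 1 carries the same methoxy group. In this assay a step of a number 6 percentage points higher from compound 2 to compound 4 (within the scatter) is expected, within the scatter. Compound 4 is estimated at 14%, with a range from 3% to 27%.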

Compound 4, a percentage reported as inhibition, at one concentration (the size of the read-out at that concentration, not a potency): 9%
Compound 4: the middle estimate sits 5 percentage points above what was measured; measured number inside the range.
By their numbers in this assay, from the lowest: compounds 3, 2 and 4 (each within the scatter of the next); then compound 1.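

Methoxy in place of hydrogen, para to a large group, leaves this assay with a number 1 percentage points higher from compound 2 to compound 4 (within the scatter), so this change does not register on the core of compound 2. For the compounds shown here, with methoxy present in both compounds, methyl in place of hydrogen on an aromatic nitrogen gives a number 12 percentage points lower from compound 1 to compound 4 (beyond the scatter), the first single-place step beyond the scatter. Nothing measured bears on the reason for either step.

As far as these compounds go, whether an amine or a carboxylic acid in place of methoxy would move the number remains open. So does the effect of a longer chain in place of the methyl on the aromatic nitrogen.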